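A few compounds are considered here, and "the series" means these few. Any claim that something is new, unique, unknown or untested is made for them only; others in the source may bear on it.

Compound 1 `N=C(NCc1ccc(O)cc1)[C@@H]1CCC(=O)N1Cc1ccccc1[N+](=O)[O-]` carries a nitro group on the ring attached to the ring nitrogen. In a functional assay on SH-SY5Y cells (Homo sapiens) for cytotoxicity, read by MTT assay, with stated times of 8 h, 30 min and 12 h, tested at 5 uM (on this read-out higher numbers stand for a stronger effect at the one concentration tested and lower numbers for a weaker effect), compound 1 gives 30.4%. Compound 2 `COc1ccc(CNC(=N)[C@@H]2CCC(=O)N2Cc2ccccc2[N+](=O)[O-])cc1` gives 25.4%, and the step of a number 5 percentage points lower from compound 1 to compound 2 (within the scatter) leaves the two within the scatter, so neither compound stands apart from the other. Compound 3 `N=C(NCc1ccc(O)cc1)[C@@H]1CCC(=O)N1Cc1ccc([N+](=O)[O-])cc1` differs from compound 1 by 4-nitrophenyl in place of 2-nitrophenyl on a saturated chain carbon bound to an amide-type nitrogen in a ring. Going by the values given here, no measured step concerns this change, since the one measured step alters a different part of the molecule. Compound 3 is therefore expected to give 30%, between 15% and 45%, an expected step of a number 0.4 percentage points lower from compound 1 to compound 3 (within the scatter) that stays within the scatter.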

Compound 3, a percentage reported as activity, at one concentration (the size of the read-out at that concentration, not a potency): 34.5%
Compound 3: middle estimate off by 4.5 percentage points, on the low side; the range from low to high includes it.
By their numbers in this assay, from the lowest: compounds 2, 1 and 3 (each within the scatter of the next).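

Swapping 2-nitrophenyl for 4-nitrophenyl on a saturated chain carbon bound to an amide-type nitrogen in a ring gives a number 4.1 percentage points higher from compound 1 to compound 3 (within the scatter) in this assay, so this read-out does not separate these two arrangements of the same atoms. Nothing available explains this result. Still open, as far as these compounds go, is whether an amine or a carboxylic acid in place of the nitro group would also leave the read-out within the scatter. Also open, from the compounds shown here alone, is how methyl in place of hydrogen on the aromatic-ring oxygen behaves alongside 4-nitrophenyl.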